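Swapping the Selenium Chain for a Methylsulfanyl Group

The compounds below may be only part of what the source reports. "The series", "measured", "known", "first", "only" and "open" are said of these compounds alone.

Compound 1 `CCCCC[Se]c1nc(N)c2ccccc2n1` carries a pentyl chain on selenium and a free amino group on the shared core. In an ADME assay on BEAS-2B cells (Homo sapiens) for cytotoxicity, read by MTT assay, with a stated time of 72 h (a lower number here means a stronger inhibitor of growth, a higher number a weaker inhibitor of growth), compound 1 reaches only > 100000 nM, which is a limit of the assay rather than a number. Compound 2 `CSc1nc(NCCCCCO)c2ccccc2n1` gives 99400 nM in this assay. Compound 3 `CCCCC[Se]c1nc(NCc2ccccc2)c2ccccc2n1` adds a benzyl group to the amine nitrogen of compound 1. In this assay compound 3 again reaches only > 100000 nM, a limit and not a number. The step that the two limits leave unreadable from compound 1 to compound 3 cannot be sized, since both of its ends sit at the limit of > 100000 nM in this assay, at which 2 of the 3 values shown sit.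

Compound 4 `CSc1nc(NCc2ccccc2)c2ccccc2n1` differs from compound 3 by a group of 2 heavy atoms (1 carbon, 1 sulfur; no ring) in place of a group of 6 heavy atoms (5 carbon, 1 selenium; no ring), on an aromatic carbon. Within the data shown here, no measured step covers this exchange. Because compound 2 gives 99400 nM while carrying the same methylsulfanyl group, the expected step of a number no higher from compound 3 to compound 4 (the limit leaves the size open) is small, within the scatter. Compound 4 is therefore estimated at 100000 nM, in the range 50000 nM to 200000 nM, and may well be reported only as a limit.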

Compound 4, concentration for total growth inhibition: 88200 nM
Compound 4: middle estimate off by 1.1-fold (0.05 log units), on the high side; measured number inside the range.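

Among these compounds, this exchange on the aromatic carbon between two ring nitrogen atoms gives the first readable comparison at this position, with an at least 1.1-fold lower number from compound 3 to compound 4 (0.05 log units; that floor lies within the scatter). Compound 3 is a limit, so this step is only a floor: the real difference may be larger, but nothing shown establishes one beyond the scatter. With methylsulfanyl in place, phenyl in place of 4-hydroxybutyl on the chain attached to the amine gives a 1.1-fold lower number from compound 2 to compound 4 (0.05 log units; within the scatter), so these two amine substituents cannot be told apart in this assay.

The exchange changes the atom bound to the ring and the chain length together, and the compounds shown cannot separate these two changes. Going by these compounds, how a pentyl chain on sulfur or a methyl group on selenium would read in this assay remains open.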